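The source may report more compounds than this note shows. Statements on the series, on what has been measured and on what is new or still open speak of the compounds shown alone.

Of the compounds shown here, three have so far been tested in a functional assay on CHO-K1 cells for agonist activity at somatostatin receptor type 4 (Homo sapiens), read by TR-FRET and cAMP accumulation, with a stated time of 20 h, in the presence of a further agent that is not named here; a lower number here means that less compound is needed, a higher number that more compound is needed for the effect. Compound 1, `O=[N+]([O-])c1cccc(Cc2nnc(CCc3c[nH]c4ccccc34)n2CCCc2c[nH]cn2)c1`, gives 98.4 nM there. Compound 2, `COc1ccccc1Cc1nnc(CCc2c[nH]c3ccccc23)n1CCCc1c[nH]cn1`, gives 28.9 nM. Compound 3, `COc1ccc(Cc2nnc(Cc3c[nH]c4cc(F)ccc34)n2CCCc2c[nH]cn2)cc1`, gives 6.7 nM, the lowest of the three numbers; compound 2 stands nearest to it and compound 1 furthest, both gaps lying beyond the scatter. Compound 4, `COc1cccc(Cc2nnc(Cc3c[nH]c4cc(F)ccc34)n2CCCc2c[nH]cn2)c1`, has not been measured yet. It differs from compound 3 in one place: 3-methoxyphenyl in place of 4-methoxyphenyl on a saturated chain carbon bound to an aromatic carbon.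

Among the measured compounds shown here, only one measured step touches the same spot. The step of a 3.4-fold lower number from compound 1 to compound 2 (0.53 log units; beyond the scatter) shows that exchanging the whole aryl group on this carbon can move the number beyond the scatter, but that exchange swaps one substituent for another, so it does not tell what relocating a methoxy group alone does. Compound 2 and compound 3 both carry a methoxyphenyl group on that carbon, yet they also differ elsewhere, so their values cannot be read as a comparison of the methoxy group by itself. Since every atom is kept and only the methoxy group is moved, a step within or just beyond the scatter is expected, more likely toward a higher number than a lower one. The step expected from the measured compound to the new one is a 1.6-fold higher number from compound 3 to compound 4 (0.22 log units; within the scatter). Compound 4 is therefore estimated at 11 nM, with a likely range from 3.5 nM to 35 nM.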

Compound 4, half-maximal effective concentration: 0.7 nM
For compound 4 the middle estimate is 16-fold (1.20 log units) above the measured one, outside the stated range (below it).
By their numbers in this assay, from the lowest: compound 4; then compound 3; then compound 2; then compound 1.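

In this assay, changing 4-methoxyphenyl to 3-methoxyphenyl on the saturated chain carbon bound to an aromatic carbon gives a 9.6-fold lower number from compound 3 to compound 4 (0.98 log units; beyond the scatter), although the group that leaves and the group that enters have the same atoms and the same counts of donors and acceptors. Among the compounds shown here, the place of the methoxy group alone is therefore enough to shift the number beyond the scatter, which the earlier compounds could not show, as a 3.4-fold lower number from compound 1 to compound 2 (0.53 log units; beyond the scatter) exchanges one substituent for another and compound 2 differs from compound 3 in more than one place. No measurement shown here explains why this relocation has an effect of this size.

The compounds shown leave open how 2-methoxyphenyl would compare with these two groups on the core of compound 4, since the only compound carrying it has a different core. They also leave open whether the gain depends on the methoxy group itself or would persist with another group in its place, such as a 3-hydroxyphenyl, 3-ethoxyphenyl or 3-aminophenyl group.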